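This account rests on a few compounds, and the source may have more. Where it says the series, first, only, none or still open, it means among the compounds named here.

Measured in an ADME assay on CEM-SS cells (Homo sapiens) for cytotoxicity, read by XTT assay, with a stated time of 6 days; a lower number here means that less compound is tolerated, a higher number that more compound is tolerated:
- Compound 1 `CCCC(=O)OCSc1ccccc1C(=O)NC1(C(N)=O)CCCC1`: > 100 uM, a limit of the assay.
- Compound 2 `CCCC(=O)OCSc1ccccc1C(=O)NC`: 5.7 uM.

Among the measured compounds shown here, compound 2, at 5.7 uM, holds the only actual number so far. Compound 3 `CCCC(=O)OCSc1ccccc1C(=O)NCC(=O)NC(C)(C)C` is reached through ((tert-butyl)carbamoyl in place of hydrogen on a saturated chain carbon bound to an amide-type nitrogen). For the measured compounds named here, the single measured step that bears on this is an at least 17-fold lower number from compound 1 to compound 2 (1.24 log units; beyond the scatter). It is large and runs the opposite way, with methyl replacing 1-carbamoylcyclopentyl on an amide-type nitrogen. Compound 3 regains a carbamoyl-bearing substituent there, so part of that step should return. A clear move to a higher number in this assay is therefore expected, a 7.0-fold higher number from compound 2 to compound 3 (0.85 log units; beyond the scatter). The estimate for compound 3 is 40 uM, within 12 uM to 100 uM.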

Compound 3, half-maximal toxic concentration: 46.8 uM
Beside the measured number, compound 3's estimate is 1.2-fold (0.07 log units) below it, and the stated range covers the measured number.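

In this assay, placing (tert-butyl)carbamoyl on the saturated chain carbon bound to the amide-type nitrogen gives an 8.2-fold higher number from compound 2 to compound 3 (0.91 log units; beyond the scatter), so a carbamoyl-bearing substituent without the 1-carbamoylcyclopentyl group recovers much of the loss seen with methyl. That recovery is incomplete, with an at least 2.1-fold lower number from compound 1 to compound 3 (0.32 log units; beyond the scatter). The value of compound 1 is a limit, so this gap is only a bound: the limit of > 100 uM in this assay, at which 1 of the 3 values shown sits.

On these data alone, it remains open whether the carbamoyl or the tert-butyl part carries the change. A longer alkyl chain, an amine or a carboxylic acid at this position could help separate them.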